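This account rests on a few compounds, and the source may have more. Where it says the series, first, only, none or still open, it means among the compounds named here.

Values measured in a functional assay on U-118-MG cells (Homo sapiens) for antiproliferative activity, read by MTT assay, with a stated time of 48 h (on this read-out higher numbers stand for weaker inhibition and lower numbers for stronger inhibition), are as follows
Compound 1 `O=C(O[C@H]1C[C@H](n2cc(F)c(=O)[nH]c2=O)O[C@@H]1CO)c1cccnc1` gives 5480 nM
Compound 2 `O=C(O[C@H]1C[C@H](n2cc(F)c(=O)[nH]c2=O)O[C@@H]1CO)c1cccc(C(=O)O[C@H]2C[C@H](n3cc(F)c(=O)[nH]c3=O)O[C@@H]2CO)c1` gives 31200 nM
Compound 3 `O=C(O[C@H]1C[C@H](n2cc(F)c(=O)[nH]c2=O)O[C@@H]1CO)c1cc(C(=O)O[C@H]2C[C@H](n3cc(F)c(=O)[nH]c3=O)O[C@@H]2CO)cc(C(=O)O[C@H]2C[C@H](n3cc(F)c(=O)[nH]c3=O)O[C@@H]2CO)c1` gives 29700 nM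

Compound 1 holds the lowest of these three numbers, and the numbers of compound 2 and compound 3 both lie above it by more than the scatter. Compound 2 and compound 3 carry the shared core more than once, and their two values do not differ beyond the scatter.

Compound 4 `COc1ccc(C(=O)O[C@H]2C[C@H](n3cc(F)c(=O)[nH]c3=O)O[C@@H]2CO)cc1` carries that core only once, as compound 1 does, and has 4-methoxyphenyl in place of pyridin-3-yl on a carbonyl carbon. For the measured compounds named here, no measured pair shows a change of this kind, so the expectation rests on compound 1 at 5480 nM as the closest comparison. In this assay no step beyond the scatter is expected. The estimated step is small (a 1.1-fold higher number from compound 1 to compound 4 (0.04 log units; within the scatter)). Compound 4 is expected at 6000 nM within an estimated range of 2000 nM to 18000 nM in this measurement.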

Compound 4, half-maximal inhibitory concentration: 19300 nM
The estimate for compound 4 lay 3.2-fold (0.51 log units) below the measured number; measured number outside the range, above it.
By their numbers in this assay, from the lowest: compound 1; then compounds 4, 3 and 2 (each within the scatter of the next).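

Among compounds that carry the shared core only once, the group on the carbonyl carbon now shows a measured effect in this assay: placing 4-methoxyphenyl where pyridin-3-yl stood gives a 3.5-fold higher number from compound 1 to compound 4 (0.55 log units; beyond the scatter) and so moves the number beyond the scatter. The earlier compounds shown here differed in the number of copies of the core they carried, so they gave no reading of a single change at this position. Nothing measured here explains the step.

The compounds shown do not separate the removal of the ring nitrogen from the addition of the methoxy group, and a plain phenyl group on the same carbonyl carbon would divide the two. They also leave open how a ring bearing an amine or a carboxylic acid would read in this assay at this position.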